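Ethoxy for methylsulfanyl on the alkyne aryl ring

The compounds below may be only part of what the source reports. "The series", "measured", "known", "first", "only" and "open" are said of these compounds alone.

Compound 1 `COc1ccc(C#Cc2ccc(C(=O)N3CCC[C@@H](CO)C3)cc2)c(F)c1`: in a functional assay on TREX cells for negative allosteric modulation of metabotropic glutamate receptor 3 (Rattus norvegicus), read by calcium flux, with a stated time of 2.5 min (a lower number here means a stronger inhibitor, a higher number a weaker inhibitor), compound 1 gives > 10000 nM, a limit of the assay.
Compound 2 `CSc1ccc(C#Cc2ccc(C(=O)N3CCC[C@@H](CO)C3)cc2)cc1`: in this assay compound 2 gives > 10000 nM, again a limit of the assay.

Both measured members of the series therefore stand at the same point, as the shared limit of > 10000 nM in this assay, at which 2 of the 2 values shown sit, shows, and the step that the two limits leave unreadable from compound 1 to compound 2 cannot be sized. Compound 2 thus carries no number at all, only a limit.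

Compound 3 `CCOc1ccc(C#Cc2ccc(C(=O)N3CCC[C@@H](CO)C3)cc2)cc1` differs from compound 2 by ethoxy in place of methylsulfanyl on an aromatic carbon. Among the measured compounds shown here, no measured step covers this exchange, and the one step on record is itself unreadable. For the measured compounds named here, the only guide is that every value so far sits at the limit (the limit of > 10000 nM in this assay, at which 2 of the 2 values shown sit), so nothing beyond the scatter can be expected from compound 2 to compound 3, a step that the limit leaves unreadable from compound 2 to compound 3 being the expected step. Compound 3 is estimated at 15000 nM, within 3000 nM to 60000 nM, most likely reported as a limit again.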

Compound 3, half-maximal inhibitory concentration: > 10000 nM
Compound 3 ended at the assay's limit; the forecaster's own chance of this, stated with the estimate: 75%; the middle value is on the limit's open side.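

Compound 3 stays at the assay limit, as do compound 1 and compound 2, so neither step to compound 3 can be read: the limit of > 10000 nM in this assay, at which 3 of the 3 values shown sit.

The compounds shown leave open whether any exchange on this aryl ring gives a measurable value in this assay.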